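The source may hold more compounds than are shown below. What is called first, only, known or untested is meant among the compounds shown, and "the series" means these compounds.

Three compounds have been measured in a functional assay on HeLa cells (Homo sapiens) for inhibition, read by MTT assay, with a stated time of 48 h; on this read-out higher numbers stand for weaker inhibition and lower numbers for stronger inhibition:

compound 1 `COc1ccc2c(=O)c(/C=C/C(=O)Nc3ccccc3)coc2c1` gives > 100000 nM in this assay.
compound 2 `COc1ccc(CNC(=O)/C=C/c2coc3cc(OC)ccc3c2=O)cc1` gives > 100000 nM in this assay.
compound 3 `COc1ccc2c(=O)c(/C=C/C(=O)NCc3ccccc3)coc2c1` gives 33400 nM in this assay.

For compound 1 the value is a limit of the assay and not a number. The same holds for compound 2, whose value is also a limit. Only compound 3 gives a number. The step of an at least 2.9-fold lower number from compound 1 to compound 3 (0.47 log units; beyond the scatter) shows that swapping the phenyl for a benzyl on the amide nitrogen improves inhibition at least modestly; the step of an at least 2.9-fold lower number from compound 2 to compound 3 (0.47 log units; beyond the scatter) points the same way, while a step that the two limits leave unreadable from compound 1 to compound 2 cannot be read.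

Compound 4 `COc1ccc2c(=O)c(/C=C/C(=O)Nc3ccccc3C)coc2c1` differs from compound 1 by methyl in place of hydrogen on an aromatic carbon. No measured step adds a group onto the phenyl of compound 1, so nothing among these compounds bears directly on this change; the only readable step from compound 1 exchanges the whole phenyl. Since compound 1 sits at the limit of > 100000 nM in this assay, at which 2 of the 3 values shown sit, compound 4 is expected to stay near that limit as well. The expected step is a number no higher from compound 1 to compound 4 (the limit leaves the size open). Compound 4 is therefore estimated at 100000 nM, with a range from 30000 nM to 300000 nM.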

Compound 4, half-maximal inhibitory concentration: 7270 nM
Compound 4: middle estimate off by 14-fold (1.14 log units), on the high side, and the stated range ends above it.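

A single methyl on the phenyl ring, ortho to a large group, is enough to bring a compound off the limit to a readable number in this assay, giving an at least 13-fold lower number from compound 1 to compound 4 (1.13 log units; beyond the scatter). The earlier compounds shown here showed a gain only from exchanging the whole group on the amide nitrogen, yet the small 2-methylphenyl change also outdoes the benzyl group, with a 4.6-fold lower number from compound 3 to compound 4 (0.66 log units; beyond the scatter), and the 4-methoxybenzyl group, with an at least 13-fold lower number from compound 2 to compound 4 (1.13 log units; beyond the scatter). The value of compound 1 remains a limit and not a number, as does that of compound 2: the limit of > 100000 nM in this assay, at which 2 of the 4 values shown sit.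

The compounds shown do not tell whether this gain belongs to methyl itself, or whether an ethyl group or a chlorine atom at the same place would give it too. They also leave open what a methyl group elsewhere on the phenyl ring would do, and they give no reason for the gain.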